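This account rests on a few compounds, and the source may have more. Where it says the series, first, only, none or still open, it means among the compounds named here.

Measured compounds:
- Compound 1 `CCC(c1ccc(-c2cscc2C)cc1)n1ccnc1` gives 27% in an assay for inhibition of steroid 17-alpha-hydroxylase/17,20 lyase (Homo sapiens), using NADPH, tested at 0.2 uM; a lower number here means a weaker effect, a higher number a stronger effect of the compound at the concentration tested
- Compound 2 `ClCc1ccc(-c2ccc(Cn3ccnc3)cc2)cn1` gives 9% in this assay
- Compound 3 `CCC(c1ccc(-c2cscc2C)cc1F)n1ccnc1` gives 41% in this assay

Among these three numbers, compound 1 stands second highest. Its nearest neighbour is compound 3, which lies higher by a number 14 percentage points higher from compound 1 to compound 3 (beyond the scatter), a step beyond the scatter that comes with fluoro in place of hydrogen on an aromatic carbon. Furthest from compound 1 is compound 2, whose number is lower, again beyond the scatter, though no single change connects those two structures.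

Compound 4 `CCC(c1ccc(-c2ccc(SC)s2)cc1)n1ccnc1` has not yet been measured. It differs from compound 1 in one place: 5-(methylsulfanyl)thiophen-2-yl in place of 4-methylthiophen-3-yl on an aromatic carbon. Among the measured compounds shown here, the only measured step, from compound 1 to compound 3, concerns a fluoro substituent and not the five-membered ring, so no measured step bears directly on this exchange. The effect of swapping one thiophene for another is therefore unknown from the numbers in hand, and the expectation must stay close to the starting point, with a wide range to either side.

On that basis compound 4 is expected to give about 30% in this assay, with a range from 10% to 55%. The expected step is therefore a number 3 percentage points higher from compound 1 to compound 4 (within the scatter), which is not clearly beyond the scatter.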

Compound 4, a percentage reported as inhibition, at one concentration (the size of the read-out at that concentration, not a potency): 2%
The estimate for compound 4 lay 28 percentage points above the measured number; measured number outside the range, below it.
By their numbers in this assay, from the lowest: compounds 4 and 2 (each within the scatter of the next); then compound 1; then compound 3.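

Among the compounds shown here, until this result, the only step on record concerned a fluoro substituent, and this is the first to bear on the five-membered ring on an aromatic carbon of a six-membered aromatic ring of carbon only. In this assay, 5-(methylsulfanyl)thiophen-2-yl in place of 4-methylthiophen-3-yl gives a number 25 percentage points lower from compound 1 to compound 4 (beyond the scatter), so the two thiophenes are not interchangeable at this position, and the direction is opposite to that of a number 14 percentage points higher from compound 1 to compound 3 (beyond the scatter). The exchange alters both the point of attachment of the ring and its substituent, and nothing available explains why the number falls.

The compounds shown do not separate the contribution of the methylsulfanyl group from that of the ring attachment, and they leave open whether a methyl group on the thiophen-2-yl ring, or a methoxy or dimethylamino group in place of the methylsulfanyl group, would restore the effect. Also open, from the compounds shown here alone, are how a furan or a phenyl ring would fare at this position and whether the fluoro exchange would raise the number on the 5-(methylsulfanyl)thiophen-2-yl series.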